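Naphthalen-1-yl replacing 1-benzothiophen-3-yl on the thioether arm

This account rests on a few compounds, and the source may have more. Where it says the series, first, only, none or still open, it means among the compounds named here.

The series shares one core and varies the arylmethyl group attached through sulfur and the substituent on the pyrazole side. Compound 1 `Cc1cc(Nc2cc(-c3ccccc3)[nH]n2)n2nc(SCc3csc4ccccc34)nc2n1` carries (1-benzothiophen-3-yl)methyl on the sulfur. In a functional assay on MCF7 cells (Homo sapiens) for inhibition, read by MTT assay, with a stated time of 72 h (on this read-out higher numbers stand for weaker inhibition and lower numbers for stronger inhibition), compound 1 gives 3470 nM, the second highest of the three numbers recorded so far. Compound 2 `Cc1cc(Nc2cc(-c3ccc(Cl)cc3)[nH]n2)n2nc(SCc3ccc(Br)cc3)nc2n1` gives 3620 nM in this assay; its number and that of compound 1 lie within the scatter of each other and show no difference. Compound 3 `Cc1cc(Nc2ccn(Cc3nc(C)c4ccccc4n3)n2)n2nc(SCc3ccc(Br)cc3)nc2n1` gives 1430 nM in this assay, a lower number than compound 1 by a gap beyond the scatter; compound 3 differs from compound 1 in more than one place, so the two values alone say nothing about any single change.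

Compound 4 `Cc1cc(Nc2cc(-c3ccccc3)[nH]n2)n2nc(SCc3cccc4ccccc34)nc2n1` is the not yet measured analogue of compound 1 and differs from it in one place: naphthalen-1-yl in place of 1-benzothiophen-3-yl on a saturated chain carbon bound to a sulfur. The group that leaves has one hydrogen-bond acceptor; the group that enters has none. For the measured compounds named here, no measured pair in the set isolates a change of this kind, so the step from compound 1 to compound 4 in this assay is expected to be small, a 1.0-fold higher number from compound 1 to compound 4 (0.00 log units; within the scatter), with no direction beyond the scatter. Compound 4 is estimated at 3500 nM, within a range from 1500 nM to 8500 nM.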

Compound 4, half-maximal inhibitory concentration: 7560 nM
For compound 4 the middle estimate is 2.2-fold (0.33 log units) below the measured one, within the range that was stated.
By their numbers in this assay, from the lowest: compound 3; then compounds 1 and 2 (each within the scatter of the next); then compound 4.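

Naphthalen-1-yl in place of 1-benzothiophen-3-yl on a saturated chain carbon bound to a sulfur gives, in this assay, a 2.2-fold higher number from compound 1 to compound 4 (0.34 log units; beyond the scatter), a modest step beyond the scatter. For the compounds shown here, this is the first comparison that isolates a single place, and it shows that the group on the thioether arm can shift the read-out with the rest of compound 1 held constant; the earlier compounds differed from one another in more than one place, so they could not separate this arm from the other varied substituent. The change swaps a five-membered aromatic ring holding sulfur, with 1 hydrogen-bond acceptor, for an all-carbon six-membered aromatic ring with none, but no supporting data tie the step to any one of these differences.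

The compounds shown leave open whether the step follows the ring sulfur or the ring size, a question that a (benzofuran-3-yl)methyl or a (thiophen-3-yl)methyl group on the sulfur would address. They also leave open whether this exchange has a similar effect when the other varied substituent is that of compound 3.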